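This account rests on a few compounds, and the source may have more. Where it says the series, first, only, none or still open, it means among the compounds named here.

Compound 2 `CN(C)C(=O)[C@H]1CC[C@@H](Nc2cc(NCc3cnccc3C(F)(F)F)ncc2C#N)CC1` gives 1800 nM in an assay on isolated protein for inhibition of protein kinase C delta type (Homo sapiens), read by TR-FRET, with a stated time of 2 h; on this read-out higher numbers stand for weaker inhibition and lower numbers for stronger inhibition. Among the measured compounds shown here, of the two numbers measured so far, it sits together with compound 1 `CNC(=O)[C@H]1CC[C@@H](Nc2cc(NCc3cnccc3C(F)(F)F)ncc2C#N)CC1`, which gives 1600 nM; the gap between them is within the scatter. For the measured compounds named here, the only measured step, a 1.1-fold higher number from compound 1 to compound 2 (0.05 log units; within the scatter), changes nothing beyond the scatter. Compound 3 `N#Cc1cnc(NCc2cnccc2C(F)(F)F)cc1N[C@H]1CC[C@@H](c2nc[nH]n2)CC1` carries 1H-1,2,4-triazol-3-yl in place of dimethylcarbamoyl on a saturated ring carbon. Going by the values given here, no measured step exchanges an amide for an aromatic ring, so that single step offers no direct guide, and the expectation rests on how little the numbers have moved so far. Compound 3 is therefore estimated at about 1500 nM, with a range from 500 nM to 5000 nM, an expected step of a 1.2-fold lower number from compound 2 to compound 3 (0.08 log units; within the scatter).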

Compound 3, half-maximal inhibitory concentration: 1200 nM
Beside the measured number, compound 3's estimate is 1.3-fold (0.10 log units) above it; measured number inside the range.
By their numbers in this assay, from the lowest: compounds 3, 1 and 2 (each within the scatter of the next).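

Exchanging the amide on the saturated ring carbon for 1H-1,2,4-triazol-3-yl is a far larger change than adding a methyl, yet in this assay it gives a 1.5-fold lower number from compound 2 to compound 3 (0.18 log units; within the scatter) and a 1.3-fold lower number from compound 1 to compound 3 (0.12 log units; within the scatter). At this position, then, a five-membered aromatic ring can stand in for either amide with no change beyond the scatter. No measurement shown here accounts for this. Still open, going by these compounds, is whether any group at this position moves the number beyond the scatter, and an amine or a carboxylic acid on the same ring carbon would test that.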